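Aminophenyl for Hydroxyphenyl on a Shared Quinazoline-like Core

The source may report more compounds than this note shows. Statements on the series, on what has been measured and on what is new or still open speak of the compounds shown alone.

Compound 1 `Fc1cccc(-c2nc(Nc3ccccc3Cl)c3cc(F)ccc3n2)c1`: in a functional assay on U2OS cells (Homo sapiens) for cytotoxicity, read by MTT assay, with a stated time of 48 h (on this read-out lower numbers stand for stronger inhibition and higher numbers for weaker inhibition), compound 1 gives > 50000 nM, which is a limit of the assay and not a number.
Compound 2 `Oc1cccc(Nc2nc(-c3cccc(F)c3)nc3ccc(F)cc23)c1`: in this assay compound 2 gives 33300 nM.

Within the data shown here, compound 2 holds the only numerical value here; the other entry, for compound 1, sits at the limit of > 50000 nM in this assay, at which 1 of the 2 values shown sits. Compound 3 `Nc1cccc(Nc2nc(-c3cccc(F)c3)nc3ccc(F)cc23)c1` differs from compound 2 by amino in place of hydroxy on an aromatic carbon. Among the measured compounds shown here, only one measured step exists, an at least 1.5-fold lower number from compound 1 to compound 2 (0.17 log units; that floor lies within the scatter), and it concerns a different swap, 3-hydroxyphenyl for 2-chlorophenyl, starting from a limit; it offers no direct guide to exchanging hydroxy for amino. For the measured compounds named here, no step therefore supports expecting a shift beyond the scatter in this assay in either direction. Compound 3 is estimated at 30000 nM, within 10000 nM to 100000 nM. That estimate means an expected step of a 1.1-fold lower number from compound 2 to compound 3 (0.05 log units; within the scatter), essentially no change.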

Compound 3, half-maximal inhibitory concentration: 49700 nM
Compound 3: the middle estimate sits 1.7-fold (0.22 log units) below what was measured, within the range that was stated.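

Amino in place of hydroxy on this aromatic carbon gives a 1.5-fold higher number from compound 2 to compound 3 (0.17 log units; within the scatter), so this assay does not tell the two groups apart at this place. This is the first comparison shown in which only the group on this carbon changes while the rest of the molecule stays the same, and exchanging the oxygen of hydroxy for the nitrogen of amino leaves the number within the usual scatter. The remaining step is a number no higher from compound 1 to compound 3 (the limit leaves the size open), and its size cannot be read. The value of compound 1 is a limit of the assay and not a number: the limit of > 50000 nM in this assay, at which 1 of the 3 values shown sits.

On these data alone, it remains open whether another group on this carbon, such as a carboxylic acid or a methoxy group, would shift the number beyond the scatter. As far as these compounds go, it is also open whether amino and hydroxy would stay this close on a different core.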